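From Butoxy to Cyclopentyloxy on a Shared Core

The source may report more compounds than this note shows. Statements on the series, on what has been measured and on what is new or still open speak of the compounds shown alone.

Of the compounds shown here, three sharing one core have been measured in a functional assay on SH-SY5Y cells (Homo sapiens) for antagonist activity, read by cAMP accumulation; on this read-out higher numbers stand for higher potency (the scale is a negative logarithm) and lower numbers for lower potency. Compound 1 `CCCCOc1ccc(Cc2ccc(NC3=NCCN3)cc2)cc1` gives 9, and compound 2 `FC(F)(F)COc1ccc(Cc2ccc(NC3=NCCN3)cc2)cc1` gives 8.7. Since a number 0.30 log units lower from compound 1 to compound 2 (within the scatter) lies within the scatter, these two stand level at the top of the three. Compound 3 `OCCOc1ccc(Cc2ccc(NC3=NCCN3)cc2)cc1` gives 8, and a number 1.00 log units lower from compound 1 to compound 3 (beyond the scatter) lies beyond the scatter, as does a number 0.70 log units lower from compound 2 to compound 3 (beyond the scatter).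

Compound 4 `c1cc(NC2=NCCN2)ccc1Cc1ccc(OC2CCCC2)cc1` has not been measured yet. It differs from compound 1 in one place: cyclopentyl in place of butyl on an oxygen on an aromatic ring. In words, this is cyclopentyl in place of butyl on an oxygen on an aromatic ring. Among the measured compounds shown here, no measured step makes this exact change, so the evidence is indirect. For the measured compounds named here, the two steps beyond the scatter both lead to compound 3, the one compound with a hydroxy group on its chain. The entering cyclopentyl, like the leaving butyl, is carbon only. As far as these compounds go, no step beyond the scatter is therefore expected in this assay, although a ring in place of a chain is untested in this small set, so a modest drop remains possible. The estimate amounts to an expected a number 0.20 log units lower from compound 1 to compound 4 (within the scatter). Compound 4 is estimated at 8.8, with an expected range of 8.2 to 9.3.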

Compound 4, negative logarithm of the antagonist equilibrium constant: 8.9
Estimate against measurement, compound 4: 0.10 log units below, and the stated range covers the measured number.
By their numbers in this assay, from the lowest: compound 3; then compounds 2, 4 and 1 (each within the scatter of the next).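

The result shows that this place, on an oxygen on an aromatic ring, accepts a five-membered non-aromatic ring of carbon only as well as it accepts the open butyl chain in this assay (a number 0.10 log units lower from compound 1 to compound 4 (within the scatter)), and the same holds against the 2,2,2-trifluoroethyl group (a number 0.20 log units higher from compound 2 to compound 4 (within the scatter)). The 2-hydroxyethyl group of compound 3 remains the one that stands apart, now also against a ring (a number 0.90 log units higher from compound 3 to compound 4 (beyond the scatter)), so every step beyond the scatter in this set still involves compound 3. Nothing measured alongside these numbers accounts for either the level result or the gap to compound 3.

As far as these compounds go, whether the tolerance extends to other rings on the same oxygen, such as cyclopropyl, cyclohexyl or phenyl, remains open, as does the outcome for a longer chain such as hexyl. From the compounds shown here alone, it is also open whether a hydroxy group placed on the cyclopentyl ring, or an amine at the end of the chain, would give a value as far from compound 1 as that of compound 3.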